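The source may hold more compounds than are shown below. What is called first, only, known or untested is meant among the compounds shown, and "the series" means these compounds.

In a functional assay on OVCAR-8 cells (Homo sapiens) for antiproliferative activity (on this read-out lower numbers stand for stronger inhibition and higher numbers for weaker inhibition), three compounds that share a core have been measured so far. Compound 2 `Cn1ncc(Cl)c1-c1cc(C(=O)N[C@@H]2CN[C@H](CC(N)=O)C[C@H]2c2ccc(Cl)c(Cl)c2)oc1Cl` gives 1000 nM and compound 1 `Cn1ncc(Cl)c1-c1cc(C(=O)N[C@@H]2CN[C@H](CCNS(C)(=O)=O)C[C@H]2c2ccc(F)c(F)c2)oc1Cl` gives 1530 nM as two values within the scatter of each other, while compound 3 `CC(=O)OCC[C@@H]1C[C@@H](c2ccc(F)c(F)c2)[C@H](NC(=O)c2cc(-c3c(Cl)cnn3C)c(Cl)o2)CN1` at 4960 nM stands clearly higher than both. Compound 4 `Cn1ncc(Cl)c1-c1cc(C(=O)N[C@@H]2CN[C@H](CCN3CCCC3)C[C@H]2c2ccc(Cl)c(Cl)c2)oc1Cl` has not been measured. The change (pyrrolidin-1-yl)methyl in place of carbamoyl on a saturated chain carbon bound to a saturated ring carbon puts (pyrrolidin-1-yl)methyl in place of carbamoyl on a saturated chain carbon bound to a saturated ring carbon of compound 2. Among the measured compounds shown here, the only measured step on this side chain is a 3.2-fold higher number from compound 1 to compound 3 (0.51 log units; beyond the scatter) for acetoxy in place of methanesulfonamido, and it is modest. For the measured compounds named here, compound 1 and compound 3 also differ from compound 2 elsewhere, and no measured compound carries the incoming group, so the data set no direction. A shift no larger than that modest step is expected in this assay and it could go either way. The estimate amounts to a 1.3-fold lower number from compound 2 to compound 4 (0.10 log units; within the scatter) as the expected step, which stays small. For compound 4 the expected value is 800 nM with an estimated range from 200 nM to 3000 nM at its two ends.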

Compound 4, half-maximal inhibitory concentration: 1840 nM
Estimate against measurement, compound 4: 2.3-fold (0.36 log units) below, within the range that was stated.
By their numbers in this assay, from the lowest: compounds 2, 1 and 4 (each within the scatter of the next); then compound 3.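

In this assay, replacing carbamoyl with (pyrrolidin-1-yl)methyl on a saturated chain carbon bound to a saturated ring carbon gives a 1.8-fold higher number from compound 2 to compound 4 (0.26 log units; within the scatter). This is the first step shown at this place on the core of compound 2, and it shows that a group of 6 heavy atoms with a five-membered non-aromatic ring and no hydrogen-bond donor can replace one of 3 heavy atoms with one such donor without a shift beyond the scatter. The data shown offer no explanation for this result. The compounds shown leave open whether a carboxylic acid or a morpholine ring at this place would give a shift beyond the scatter. They also leave open whether (pyrrolidin-1-yl)methyl would give a similar step on the core of compound 1.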